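Changing the Halogen Ring Partner on a Shared Core

The source may report more compounds than this note shows. Statements on the series, on what has been measured and on what is new or still open speak of the compounds shown alone.

Of the compounds shown here, two have been tested in a functional assay on U-251 cells (Homo sapiens) for inhibition, read by sulforhodamine B assay, with a stated time of 48 h, tested at 10 uM; on this read-out lower numbers stand for less inhibition and higher numbers for more inhibition at the one concentration tested (going by the name of the read-out). Compound 1 `O=Cc1ccc(-c2cn3ccnc3c(-c3ccc4ncn(C5CCCCC5)c4c3)n2)cc1` gives 32% in this assay, and compound 2 `Brc1ccc(-c2cn3ccnc3c(-c3ccc4ncn(C5CCCCC5)c4c3)n2)cc1` gives 23.7%. For the measured compounds named here, the nearest neighbour of compound 2 on these numbers is compound 1, and the single step that separates them, a number 8.3 percentage points lower from compound 1 to compound 2 (within the scatter), lies within the scatter, so the two values cannot be told apart. Compound 3 `Fc1ccccc1-c1cn2ccnc2c(-c2ccc3ncn(C4CCCCC4)c3c2)n1` differs from compound 2 in one place: 2-fluorophenyl in place of 4-bromophenyl on an aromatic carbon. Going by the values given here, the only measured step, bromo in place of formyl on an aromatic carbon, stayed within the scatter; it also concerns a six-membered aromatic ring of carbon only, but not the same kind of exchange, so it offers only a weak guide. No step beyond the scatter is expected, that is a number 1.3 percentage points higher from compound 2 to compound 3 (within the scatter). Compound 3 is therefore estimated to give 25% in this assay, with a range from 5% to 45%.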

Compound 3, a percentage reported as inhibition, at one concentration (the size of the read-out at that concentration, not a potency): 11.4%
Beside the measured number, compound 3's estimate is 13.6 percentage points above it, and the stated range covers the measured number.
By their numbers in this assay, from the lowest: compound 3; then compounds 2 and 1 (each within the scatter of the next).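

In this assay, for the compounds shown here, the position on the shared core does respond to the group it carries: 2-fluorophenyl in place of 4-bromophenyl gives a number 12.3 percentage points lower from compound 2 to compound 3 (beyond the scatter), and 2-fluorophenyl in place of 4-formylphenyl gives a number 20.6 percentage points lower from compound 1 to compound 3 (beyond the scatter), while the one earlier step stayed within the scatter. Compound 3 therefore reads lowest of the three, and the exchange from compound 2 to compound 3 does this with the same count of heavy atoms and the same single ring, so those counts alone do not set the number. Nothing measured here says why the number falls.

The compounds shown leave open whether the lower number goes with fluorine or with where the halogen sits on the phenyl ring, as both differ together; a 4-fluorophenyl group would separate the two. Going by these compounds, how a phenyl ring carrying an amine or a carboxylic acid would read also remains open.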